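Hydroxy to Bromo: One Change, a Large Gain Expected

A few compounds are considered here, and "the series" means these few. Any claim that something is new, unique, unknown or untested is made for them only; others in the source may bear on it.

Compound 1, `CCCc1cc(N)c2cc(NC(=O)/C=C/c3ccc(O)cc3)ccc2n1`, 1100 nM
Compound 2, `CC(C)c1cc(N)c2cc(NC(=O)/C=C/c3ccc(C(F)(F)F)cc3)ccc2n1`, 2.1 nM
Compound 3, `CCCc1cc(N)c2cc(NC(=O)C3CCC(c4ccc(Cl)cc4)CC3)ccc2n1`, 4.4 nM

In an assay on isolated protein for displacement of a labelled ligand from melanin-concentrating hormone receptor 1 (Homo sapiens) (a higher number here means a weaker inhibitor, a lower number a stronger inhibitor), compound 1 gives the highest of the three numbers, 1100 nM. Compound 2 gives 2.1 nM and compound 3 gives 4.4 nM; both lie far below compound 1, well beyond the scatter, though neither differs from compound 1 in one place alone, so no single step can be read from them.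

Compound 4, `CCCc1cc(N)c2cc(NC(=O)/C=C/c3ccc(Br)cc3)ccc2n1`, differs from compound 1 by bromo in place of hydroxy on an aromatic carbon. Going by the values given here, no measured pair shows this change by itself. Both compound 2 and compound 3 lack a hydroxy group and give far lower numbers than compound 1. A large downward step is therefore expected a 220-fold lower number from compound 1 to compound 4 (2.34 log units; beyond the scatter). Compound 4 is estimated at 5 nM, with a range from 1.5 nM to 25 nM.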

Compound 4, half-maximal inhibitory concentration: 4 nM
Estimate against measurement, compound 4: 1.3-fold (0.10 log units) above; low and high end bracket the measured number.
By their numbers in this assay, from the lowest: compounds 2, 4 and 3 (each within the scatter of the next, the first and the last beyond it); then compound 1.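

With only one place changed, the effect can now be read directly: going from 4-hydroxyphenyl to 4-bromophenyl gives a 280-fold lower number from compound 1 to compound 4 (2.44 log units; beyond the scatter) in this assay. Compound 2 and compound 3 differ from compound 1 in more than one place, so they could not show that this single replacement, on the aromatic carbon para to a large group, is enough for a step of this size. No evidence here explains the gain.

Going by these compounds, whether bromo is special at this position remains open, since an amine, a methoxy group or a fluoro group there could give a different number. On these data alone, it is also open whether the same replacement would give a similar step on another compound.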